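Hydrogen for methyl on the ring nitrogen: compound 4

The source may report more compounds than this note shows. Statements on the series, on what has been measured and on what is new or still open speak of the compounds shown alone.

Compound 2 `Cn1nc(N)c(/N=N/c2ccc(O)cc2)c1N` gives 98500 nM in a functional assay on K562 cells (Homo sapiens) for cytotoxicity, read by fluorescence, with a stated time of 72 h (on this read-out lower numbers stand for stronger inhibition and higher numbers for weaker inhibition), the highest of the two numbers shown; compound 3 `Nc1n[nH]c(N)c1/N=N/c1cccc[n+]1[O-]` gives 62600 nM, a gap within the scatter. Compound 1 `CCOC(=O)n1nc(N)c(/N=N/c2ccc(O)cc2)c1N` reports only a limit, > 100000 nM. For the measured compounds named here, the one measured step at this ring nitrogen, an at least 1.0-fold lower number from compound 1 to compound 2 (0.00 log units; that floor lies within the scatter), sits at the floor set by the limit of > 100000 nM in this assay, at which 1 of the 3 values shown sits, and so says little. Compound 4 `Nc1n[nH]c(N)c1/N=N/c1ccc(O)cc1` differs from compound 2 by hydrogen in place of methyl on an aromatic nitrogen. Going by the values given here, no measured step covers hydrogen replacing methyl on this nitrogen; compound 3 carries hydrogen there but a different aryl group, so its value is only a loose reference. Compound 4 is therefore expected at 80000 nM, with a range from 30000 nM to 250000 nM. The expected step is a 1.2-fold lower number from compound 2 to compound 4 (0.09 log units; within the scatter), not beyond the scatter.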

Compound 4, half-maximal inhibitory concentration: 33000 nM
For compound 4 the middle estimate is 2.4-fold (0.38 log units) above the measured one, within the range that was stated.
By their numbers in this assay, from the lowest: compounds 4, 3 and 2 (each within the scatter of the next, the first and the last beyond it). At a limit, above all of these: compound 1.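

At this ring nitrogen, this assay now gives a step that can be read, where the earlier step sat at its floor: hydrogen in place of methyl gives a 3.0-fold lower number from compound 2 to compound 4 (0.47 log units; beyond the scatter). Hydrogen in place of ethoxycarbonyl gives an at least 3.0-fold lower number from compound 1 to compound 4 (0.48 log units; beyond the scatter). That second step is only a floor, since compound 1 stands at a limit: the limit of > 100000 nM in this assay, at which 1 of the 4 values shown sits.

Open, on these data alone, is where an ethyl or an acetyl group on this nitrogen would fall relative to compound 2 and compound 4. Also open, as far as these compounds go, is whether hydrogen in place of methyl gives a similar step with a different aryl group on the shared core.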